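Removing the chloro from compound 1: stability notes

The source may report more compounds than this note shows. Statements on the series, on what has been measured and on what is new or still open speak of the compounds shown alone.

- compound 1 `CC(C)COc1ncc(-c2cn(C)c3cc(C(=O)NS(=O)(=O)C4CC4)c(F)cc23)cc1Cl` at 100%
- compound 2 `CC(C)COc1ccc(-c2nn(C)c3cc(C(=O)NS(=O)(=O)C4CC4)c(F)cc23)cn1` at 91%
- compound 3 `Cn1cc(-c2ccc(C(F)F)cc2)c2cc(F)c(C(=O)NS(=O)(=O)C3CC3)cc21` at 93%

In an ADME assay on microsomes from liver (Homo sapiens) for metabolic stability, with a stated time of 10 min, tested at 0.5 uM (a higher number here means that more of the compound is left, a lower number that less of the compound is left), compound 1 lies within the scatter of both compound 2 and compound 3, so the three values form one level group. Compound 4 `CC(C)COc1ccc(-c2cn(C)c3cc(C(=O)NS(=O)(=O)C4CC4)c(F)cc23)cn1` differs from compound 1 by hydrogen in place of chloro on an aromatic carbon with hydrogen in place of chloro on an aromatic carbon. Going by the values given here, no measured pair isolates this change. Compound 2 also lacks the chloro and gives 91% on a different core, which offers only indirect support. The estimated a number 8 percentage points lower from compound 1 to compound 4 (within the scatter) is small, downward if anything, and expected to stay within the scatter of this assay in this series. For compound 4 the expected value is 92% with an estimated range from 80% to 100% as the working figure.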

Compound 4, percent of the compound remaining: 100%
For compound 4 the middle estimate is 8 percentage points below the measured one; low and high end bracket the measured number.
By their numbers in this assay, from the lowest: compounds 2, 3, 1 and 4 (each within the scatter of the next).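

In this assay, hydrogen in place of chloro on the aromatic carbon ortho to an isobutoxy group now has a direct reading: no change at the digits printed from compound 1 to compound 4 (within the scatter). Going by these compounds alone, this is the first matched pair at this position, and it shows that on the core of compound 1 the chloro can be lost without a measurable change in the percent remaining. No available finding explains this tolerance. Still open, going by these compounds, is how a methyl, a methoxy or a nitrile at this position would read in this assay, and whether an amine would be tolerated there.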